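This account rests on a few compounds, and the source may have more. Where it says the series, first, only, none or still open, it means among the compounds named here.

Measured so far:
compound 1 `COc1ccc(-c2cn(C[C@H](O)[C@H]3OC(=O)C(OCc4ccccc4)=C3OCc3ccccc3)nn2)cc1` — < 10 nM
compound 2 `O=C1O/C(=C\Cn2cc(-c3cccc(O)c3)nn2)C(OCc2ccccc2)=C1OCc1ccccc1` — 42600 nM

Of the compounds shown here, two sharing the same core have been tested in an ADME assay on HFF cells (Homo sapiens) for cytotoxicity, read by MTT assay, with a stated time of 72 h; on this read-out higher numbers stand for weaker inhibition and lower numbers for stronger inhibition. Among the measured compounds shown here, for compound 1 the result is only a limit of the assay, < 10 nM, not a number, so it is known only that compound 1 sits at the limit of < 10 nM in this assay, at which 1 of the 2 values shown sits. In this assay compound 2 gives 42600 nM; the two compounds differ at more than one place, so no single change can be tied to the gap between them.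

Compound 3 `O=C1O[C@H]([C@@H](O)Cn2cc(-c3ccc(Br)cc3)nn2)C(OCc2ccccc2)=C1OCc1ccccc1` has not yet been measured in this assay. It differs from compound 1 in one place: bromo in place of methoxy on an aromatic carbon. Bromo enters where methoxy leaves, on the six-membered aromatic ring, para to a large group. For the measured compounds named here, no measured pair shows what this change does here, so any expectation rests on compound 1 alone, whose value is only a limit.

With so little to go on, compound 3 is expected to stay near compound 1, the step from an at least 2.0-fold higher number from compound 1 to compound 3 (0.30 log units; that floor lies within the scatter) being small, possibly none beyond the usual scatter. The estimate for compound 3 in this assay is 20 nM, in a range from 4 nM to 300 nM.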

Compound 3, half-maximal inhibitory concentration: 5100 nM
For compound 3 the middle estimate is 260-fold (2.41 log units) below the measured one, and the stated range ends below it.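

In this assay, putting bromo in place of methoxy gives an at least 510-fold higher number from compound 1 to compound 3 (2.70 log units; beyond the scatter). Among the compounds shown here, this is the first single-place comparison, and it shows that the group on the six-membered aromatic ring, para to a large group, strongly affects the read-out, with the bromo compound giving the weaker inhibition of the two. The step is only a floor because compound 1 stands at a limit of the assay, not at a number: the limit of < 10 nM in this assay, at which 1 of the 3 values shown sits.

For the compounds shown here, with only two groups compared at this place, it remains open whether methoxy is unusual in giving so strong an inhibition or bromo is unusual in weakening it. From the compounds shown here alone, how an amine or a carboxylic acid would read at the same place is unknown, as is whether this change would have a similar effect on compound 2.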